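Working notes: from compound 1 to compound 3

The source may report more compounds than this note shows. Statements on the series, on what has been measured and on what is new or still open speak of the compounds shown alone.

In a functional assay on A549 cells (Homo sapiens) for inhibition, read by sulforhodamine B assay, with a stated time of 48 h, tested at 50 uM (a lower number here means less inhibition of growth, a higher number more inhibition of growth at the concentration tested), compound 1 (`COc1ccc([C@@H]2C/C(=N/OCc3cn(-c4ccc(Cl)cc4C)nn3)c3cc(CC=C(C)C)c(OC)cc3O2)cc1`) gives 35%. This is the lower of the two numbers available. Compound 2 (`COc1cc2c(cc1CC=C(C)C)/C(=N/O)C[C@@H](c1ccc(O)cc1)O2`) gives 80%, a gap well beyond the scatter. Among the compounds with values here, no measured pair differs in only one place, so this gap cannot be assigned to any single group.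

Compound 3 (`COc1ccc([C@@H]2C/C(=N/OCc3cn(-c4cccnc4Cl)nn3)c3cc(CC=C(C)C)c(OC)cc3O2)cc1`) carries 2-chloropyridin-3-yl in place of 4-chloro-2-methylphenyl on an aromatic nitrogen of a five-membered aromatic ring with 3 nitrogen, and the rest of compound 1 is kept (2-chloropyridin-3-yl in place of 4-chloro-2-methylphenyl on an aromatic nitrogen). Nothing measured isolates this exchange, so the expectation stays anchored on compound 1 at 35%. No shift beyond the scatter is expected in this assay, with only a slight upward lean. The expected change is a number 3 percentage points higher from compound 1 to compound 3 (within the scatter). For compound 3, the estimated value is 38%, with an expected range of 20% to 56%.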

Compound 3, percent growth inhibition at one concentration: 58%
Compound 3: the middle estimate sits 20 percentage points below what was measured; the measured number lies above the stated range.
By their numbers in this assay, from the lowest: compound 1; then compound 3; then compound 2.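

In this assay, within the data shown here, the exchange on an aromatic nitrogen of the five-membered aromatic ring with 3 nitrogen gives a number 23 percentage points higher from compound 1 to compound 3 (beyond the scatter) and so provides the first single-place comparison. It shows that this position is not indifferent to the aromatic group it carries, and that 2-chloropyridin-3-yl reads higher here than 4-chloro-2-methylphenyl on the core of compound 1. No measurement available here accounts for this step.

As far as these compounds go, the exchange alters several features together, replacing a carbon-only ring with a ring holding 1 hetero atom and changing the ring's other substituents, so the part responsible for the step remains open. Also open, from the compounds shown here alone, is how a plain phenyl, a 2-chlorophenyl or a phenyl bearing a carboxylic acid would read on the same aromatic nitrogen.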